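A Furan for a Thiophene on a Hydroxamate Chain

The compounds below may be only part of what the source reports. "The series", "measured", "known", "first", "only" and "open" are said of these compounds alone.

Measured compounds:
Compound 1, `O=C(CCC(=O)Nc1nnc(-c2ccc(O)cc2)s1)NO`: 14700 nM
Compound 2, `NC(=O)N1N=C(c2ccccc2)CC1c1ccccc1OCC(=O)NO`: 18700 nM
Compound 3, `Cc1ccc(-c2nnc(NC(=O)CCCCCCC(=O)NO)s2)s1`: 880 nM

All three were tested in a functional assay on PC-3 cells (Homo sapiens) for inhibition, read by MTT assay; a higher number here means a weaker inhibitor, a lower number a stronger inhibitor. Compound 3 stands lowest of the three numbers, and both compound 1 and compound 2 lie well beyond the scatter above it, so compound 3 is the strongest inhibitor shown here.

Compound 4, `Cc1ccc(-c2nnc(NC(=O)CCCCCCC(=O)NO)s2)o1`, has not yet been measured. It differs from compound 3 in one place: 5-methylfuran-2-yl in place of 5-methylthiophen-2-yl on an aromatic carbon. For the measured compounds named here, no measured pair shows this kind of swap, so there is no direct guide to its size. The change keeps the ring size, the hetero atom count and the methyl group, so only a small step is expected from compound 3 to compound 4, a 1.4-fold higher number from compound 3 to compound 4 (0.13 log units; within the scatter), and not beyond the scatter.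

Compound 4 is therefore estimated at 1200 nM, within a range of 400 nM to 3600 nM.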

Compound 4, half-maximal inhibitory concentration: 880 nM
The estimate for compound 4 lay 1.4-fold (0.13 log units) above the measured number; the measured number falls inside the stated range.
By their numbers in this assay, from the lowest: compounds 3 and 4 (each within the scatter of the next); then compounds 1 and 2 (each within the scatter of the next).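

Putting 5-methylfuran-2-yl in place of 5-methylthiophen-2-yl gives no change at the digits printed from compound 3 to compound 4 (within the scatter) in this assay. This is the only pair shown that differs in one place, and it gives this position its first direct reading: on this shared core, a ring oxygen can stand where the ring sulfur stood without a change that can be told from scatter. No supporting measurement bears on this result. Still open, from the compounds shown here alone, is whether a pyridin-2-yl ring, or a furan-2-yl ring without the methyl group, would also hold the number at this position.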